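Amide aryl swap on a shared bicyclic core

The source may report more compounds than this note shows. Statements on the series, on what has been measured and on what is new or still open speak of the compounds shown alone.

Measured so far:
Compound 1 `O=C(c1ccccc1F)N1CCc2oc(-c3ccc(F)cn3)nc2C1`: 58 nM
Compound 2 `COc1cccc(C(=O)N2CCc3oc(-c4ccc(F)cn4)nc3C2)c1`: 157 nM

In a functional assay on HEK293 cells for negative allosteric modulation of metabotropic glutamate receptor 5 (Homo sapiens), read by fluorescence and calcium flux, with a stated time of 2 min (a higher number here means a weaker inhibitor, a lower number a stronger inhibitor), compound 2 gives 157 nM, the higher of the two numbers, with compound 1 nearest at a 2.7-fold higher number from compound 1 to compound 2 (0.43 log units; beyond the scatter). Compound 3 `Cc1cc(Cl)cc(C(=O)N2CCc3oc(-c4ccc(F)cn4)nc3C2)c1` carries the change (3-chloro-5-methylphenyl in place of 3-methoxyphenyl on a carbonyl carbon). For the measured compounds named here, no measured step touches this exchange; the only step known, that from compound 1 to compound 2, was modest. A step of similar size, in either direction, is therefore expected in this assay. Compound 3 is estimated at 80 nM, between 25 nM and 300 nM, which would mean a 2.0-fold lower number from compound 2 to compound 3 (0.29 log units; within the scatter).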

Compound 3, half-maximal inhibitory concentration: 46 nM
Compound 3: the middle estimate sits 1.7-fold (0.24 log units) above what was measured, and the stated range covers the measured number.
By their numbers in this assay, from the lowest: compounds 3 and 1 (each within the scatter of the next); then compound 2.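

The exchange of 3-methoxyphenyl for 3-chloro-5-methylphenyl on the carbonyl carbon gives a 3.4-fold lower number from compound 2 to compound 3 (0.53 log units; beyond the scatter) in this assay, so this position responds to a change in its aryl group in the direction opposite to the first step. The other comparison, a 1.3-fold lower number from compound 1 to compound 3 (0.10 log units; within the scatter), shows that 2-fluorophenyl and 3-chloro-5-methylphenyl cannot be told apart here. Nothing available explains either result.

From the compounds shown here alone, whether 3-chlorophenyl or 3-methylphenyl alone would match compound 3 remains open. So does the outcome of a pyridine ring or a carboxylic acid at this position.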